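Aryl hydrazone exchange in the semicarbazide series

A few compounds are considered here, and "the series" means these few. Any claim that something is new, unique, unknown or untested is made for them only; others in the source may bear on it.

Measured so far in a functional assay on MKN-45 cells (Homo sapiens) for cytotoxicity, read by MTT assay, with a stated time of 72 h; on this read-out lower numbers stand for stronger inhibition and higher numbers for weaker inhibition:
Compound 1 `CN(C)CCn1cnnc1-c1cc(Oc2ccc(NC(=O)N/N=C/c3ccc(O)c(F)c3)cc2F)ccn1` gives 1970 nM.
Compound 2 `COc1ccc(/C=N/NC(=O)Nc2ccc(Oc3ccnc(-c4nncn4CCN(C)C)c3)c(F)c2)cc1O` gives 2510 nM.

Compound 2 sits alongside compound 1 in this assay, the two numbers lying within the scatter of each other. Compound 3 `Cc1cc(/C=N/NC(=O)Nc2ccc(Oc3ccnc(-c4nncn4CCN(C)C)c3)c(F)c2)cc(C)c1O` is the next variation: 4-hydroxy-3,5-dimethylphenyl in place of 3-hydroxy-4-methoxyphenyl on a carbon with a double bond to nitrogen. Among the measured compounds shown here, the only measured step that bears on it is the earlier exchange of the same aryl group, a 1.3-fold higher number from compound 1 to compound 2 (0.11 log units; within the scatter), which moved nothing beyond the scatter. For the measured compounds named here, with that as the sole guide, no step beyond the scatter is expected, the estimated change being a 1.0-fold lower number from compound 2 to compound 3 (0.00 log units; within the scatter). Compound 3 is therefore expected at 2500 nM, within a range from 1100 nM to 5500 nM.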

Compound 3, half-maximal inhibitory concentration: 1510 nM
For compound 3 the middle estimate is 1.7-fold (0.22 log units) above the measured one; measured number inside the range.
By their numbers in this assay, from the lowest: compounds 3, 1 and 2 (each within the scatter of the next).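

In this assay, the aryl group on the carbon with a double bond to nitrogen takes a third form, 4-hydroxy-3,5-dimethylphenyl, with a 1.7-fold lower number from compound 2 to compound 3 (0.22 log units; within the scatter) and a 1.3-fold lower number from compound 1 to compound 3 (0.12 log units; within the scatter). Methyl groups thus stand in for the fluorine of compound 1 and the methoxy of compound 2 without any step beyond the scatter. No other data bear on this result.

Still open, on these data alone, is whether an aryl group carrying an amine or a carboxylic acid would stay within the scatter of these three compounds.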